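A dimethylphenyl amide replaces the chlorophenyl on the shared core

The source may hold more compounds than are shown below. What is called first, only, known or untested is meant among the compounds shown, and "the series" means these compounds.

Among the three measured compounds, compound 2 `Cc1c(O)c(=O)ccn1CC(=O)N/N=C1\C(=O)N(CC(=O)Nc2ccc(Cl)cc2)c2ccccc21` stands lowest in a functional assay on MCF7 cells (Homo sapiens) for cytotoxicity, read by MTT assay, with a stated time of 48 h (on this read-out lower numbers stand for an effect already at smaller amounts and higher numbers for an effect only at larger amounts of compound), with 31400 nM. Compound 1 `Cc1c(O)c(=O)ccn1CC(=O)N/N=C1\C(=O)N(CC(=O)Nc2ccc(Br)cc2)c2ccccc21` gives 32500 nM and compound 3 `Cc1c(O)c(=O)ccn1CC(=O)N/N=C1\C(=O)N(CC(=O)Nc2ccccc2Cl)c2ccccc21` gives 46400 nM; the step of a 1.0-fold lower number from compound 1 to compound 2 (0.01 log units; within the scatter) and the step of a 1.5-fold higher number from compound 2 to compound 3 (0.17 log units; within the scatter) both fall within the scatter, so no order can be drawn among the three. Compound 4 `Cc1cccc(NC(=O)CN2C(=O)/C(=N\NC(=O)Cn3ccc(=O)c(O)c3C)c3ccccc32)c1C` differs from compound 2 by 2,3-dimethylphenyl in place of 4-chlorophenyl on an amide-type nitrogen. Both measured steps touch the same phenyl on the amide-type nitrogen, and neither moved the number beyond the scatter, so a change of similarly small size, if any, is expected here, with the direction uncertain. Compound 4 is therefore estimated to give 36000 nM in this assay, within 15000 nM to 85000 nM, an expected step of a 1.1-fold higher number from compound 2 to compound 4 (0.06 log units; within the scatter).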

Compound 4, half-maximal effective concentration: 51900 nM
Compound 4: the middle estimate sits 1.4-fold (0.16 log units) below what was measured; measured number inside the range.
By their numbers in this assay, from the lowest: compounds 2, 1, 3 and 4 (each within the scatter of the next).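

In this assay, 2,3-dimethylphenyl on the amide-type nitrogen, a ring with no halogen, leaves every step within the scatter (a 1.7-fold higher number from compound 2 to compound 4 (0.22 log units; within the scatter); a 1.6-fold higher number from compound 1 to compound 4 (0.20 log units; within the scatter); a 1.1-fold higher number from compound 3 to compound 4 (0.05 log units; within the scatter)). Among these four compounds, then, neither chlorine nor bromine on this phenyl is needed for a number in this range, and two carbon substituents on the ring fit the same picture. Nothing available bears on why these numbers lie where they do. From the compounds shown here alone, it remains open whether a phenyl carrying a carboxylic acid or an amine, or a longer alkyl chain in place of the phenyl, would move the number beyond the scatter.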